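Dichloroanilino series: dropping one chloro substituent

The compounds below may be only part of what the source reports. "The series", "measured", "known", "first", "only" and "open" are said of these compounds alone.

Measured compounds:
compound 1, `Oc1ccc(Nc2cncc(N3CC4CC(C3)N4)c2)cc1`, 0.342 nM
compound 2, `Clc1ccc(Nc2cncc(N3CC4CC(C3)N4)c2)cc1Cl`, 1.25 nM

Both compounds share the same core and differ only in the substituents on the anilino ring. In an assay on cell membranes for displacement of a labelled ligand from Neuronal acetylcholine receptor; alpha4/beta2 (Rattus norvegicus) (on this read-out lower numbers stand for stronger inhibition and higher numbers for weaker inhibition), compound 1 gives 0.342 nM and compound 2 gives 1.25 nM. Compound 2 therefore stands at the higher of the two numbers shown, and its gap to compound 1 is beyond the usual scatter. As these two differ in more than one place, no single step can be read from them.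

The next compound, compound 3, `Clc1cccc(Nc2cncc(N3CC4CC(C3)N4)c2)c1`, keeps one chloro substituent and removes the other. The change from compound 2 is hydrogen in place of chloro on an aromatic carbon. Going by the values given here, no step of this kind is on record, so the direction cannot be taken from measured pairs. Removing a single chloro substituent on an already substituted anilino ring is expected to move this assay little, in either direction, and not beyond the scatter. Compound 3 is expected to give 1 nM, within 0.3 nM to 3.5 nM. This estimate means a step of a 1.3-fold lower number from compound 2 to compound 3 (0.10 log units; within the scatter), expected to lie inside the scatter.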

Compound 3, inhibition constant: 0.124 nM
Compound 3: the middle estimate sits 8.1-fold (0.91 log units) above what was measured; measured number below the stated range.
By their numbers in this assay, from the lowest: compound 3; then compound 1; then compound 2.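

Going by these compounds alone, the chloro group on the aromatic carbon ortho to a chloro group and para to a large group proves not to be a neutral substituent in this assay: hydrogen in its place gives a 10-fold lower number from compound 2 to compound 3 (1.00 log units; beyond the scatter), the first single-place change on record, and it shows that this position strongly affects the read-out. The broader exchange of 4-hydroxyphenyl for 3-chlorophenyl on the nitrogen gives a 2.8-fold lower number from compound 1 to compound 3 (0.44 log units; beyond the scatter), so a single chloro group on the anilino ring is compatible with the lowest number of the three compounds, and compound 3 stands as the strongest inhibitor among them. Nothing at hand bears on why removing this chloro group lowers the number.

Going by these compounds, it remains open whether a fluoro or methoxy group on that same aromatic carbon would keep the number near that of compound 3 or return it towards that of compound 2. Within the data shown here, it is also open whether the effect depends on the remaining chloro group, as only one pair carries this change.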